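The source may hold more compounds than are shown below. What is called first, only, known or untested is meant among the compounds shown, and "the series" means these compounds.

Compound 2, `COc1cc(/C=C/C(=O)N2c3cc(O[C@@H]4O[C@H](CO[C@@H]5O[C@H](CO)[C@@H](O)[C@H](O)[C@H]5OC(=O)/C=C/c5ccc(O)c(O)c5)[C@@H](O)[C@H](O)[C@H]4O)c(O)cc3C[C@H]2C(=O)O)ccc1O`, gives 16100 nM in a physicochemical assay, with a stated time of 30 min (a higher number here means that more compound is needed for the effect, a lower number that less compound is needed), and stands lowest of the three numbers measured. Compound 3, `COc1cc(/C=C/C(=O)O[C@H]2[C@H](OC[C@H]3O[C@@H](Oc4cc5c(cc4O)C[C@@H](C(=O)O)N5C(=O)/C=C/c4ccc(O)cc4)[C@H](O)[C@@H](O)[C@@H]3O)O[C@H](CO)[C@@H](O)[C@@H]2O)ccc1O`, gives 29100 nM, within the scatter of compound 2, while compound 1, `COc1cc(/C=C/C(=O)N2c3cc(O[C@@H]4O[C@H](CO[C@@H]5O[C@H](CO)[C@@H](O)[C@H](O)[C@H]5O)[C@@H](O)[C@H](O)[C@H]4O)c(O)cc3C[C@H]2C(=O)O)ccc1O`, gives 40100 nM. For the measured compounds named here, the only measured step, a 2.5-fold lower number from compound 1 to compound 2 (0.40 log units; beyond the scatter), concerns a different part of the molecule and so offers little guidance here. Compound 4, `COc1cc(/C=C/C(=O)O[C@H]2[C@H](OC[C@H]3O[C@@H](Oc4cc5c(cc4O)C[C@@H](C(=O)O)N5C(=O)/C=C/c4ccc(O)c(OC)c4)[C@H](O)[C@@H](O)[C@@H]3O)O[C@H](CO)[C@@H](O)[C@@H]2O)ccc1O`, differs from compound 2 by methyl in place of hydrogen on an oxygen on an aromatic ring. Compound 2 and compound 3, which differ in the same part of the molecule, give numbers within the scatter of each other, so a small change is expected, a 1.2-fold higher number from compound 2 to compound 4 (0.09 log units; within the scatter), not beyond the scatter. Compound 4 is therefore estimated at 20000 nM, with a range from 9000 nM to 45000 nM.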

Compound 4, half-maximal effective concentration: 27600 nM
Compound 4: middle estimate off by 1.4-fold (0.14 log units), on the low side; measured number inside the range.
By their numbers in this assay, from the lowest: compounds 2, 4, 3 and 1 (each within the scatter of the next, the first and the last beyond it).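

In this assay, methyl in place of hydrogen on the oxygen on the aromatic ring gives a 1.7-fold higher number from compound 2 to compound 4 (0.23 log units; within the scatter) while methoxy in place of hydrogen on an aromatic carbon gives a 1.1-fold lower number from compound 3 to compound 4 (0.02 log units; within the scatter) and so neither change at this position moves the number beyond the scatter. For the compounds shown here, these two steps are the first direct readings here, where the earlier compounds offered only the gap between compound 2 and compound 3. Nothing measured here explains why these steps are small. On these data alone, whether a longer chain on this oxygen, or an amine in place of the hydroxy, would move the number beyond the scatter remains open.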